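Heteroaryl ketone in place of dimethoxyphenyl on compound 2

The compounds below may be only part of what the source reports. "The series", "measured", "known", "first", "only" and "open" are said of these compounds alone.

Three analogues are measured so far: compound 1 `COc1ccc(C(=O)/C=C/c2nc3ccccc3cc2-c2ccc(OC)cc2)cc1`, compound 2 `COc1ccc(-c2cc3ccccc3nc2/C=C/C(=O)c2ccc(OC)cc2OC)cc1` and compound 3 `COc1ccc(-c2cc3ccccc3nc2/C=C/C(=O)c2ccccn2)cc1`. In a functional assay on SK-BR-3 cells (Homo sapiens) for antiproliferative activity, read by XTT assay, with a stated time of 72 h (on this read-out lower numbers stand for stronger inhibition and higher numbers for weaker inhibition), compound 1 gives 9280 nM and compound 3 gives 370 nM. Compound 2 stands second highest of the three numbers in this assay with 2260 nM; the first step is a 4.1-fold lower number from compound 1 to compound 2 (0.61 log units; beyond the scatter).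

Compound 4 `COc1ccc(-c2cc3ccccc3nc2/C=C/C(=O)c2cnc(N)nc2C)cc1` is not yet measured. Relative to compound 2 the change is 2-amino-4-methylpyrimidin-5-yl in place of 2,4-dimethoxyphenyl on a carbonyl carbon. Within the data shown here, the steps that bear on this replacement on the carbonyl carbon are a 6.1-fold lower number from compound 2 to compound 3 (0.79 log units; beyond the scatter) and a 25-fold lower number from compound 1 to compound 3 (1.40 log units; beyond the scatter); both move the number down beyond the scatter when a nitrogen-containing six-membered aromatic ring enters in place of a methoxyphenyl group. The entering 2-amino-4-methylpyrimidin-5-yl differs from pyridin-2-yl, so the step expected here is more cautious: a 2.8-fold lower number from compound 2 to compound 4 (0.45 log units; beyond the scatter). Compound 4 is therefore estimated at 800 nM in this assay, with a likely range from 200 nM to 3000 nM.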

Compound 4, half-maximal inhibitory concentration: > 10000 nM
Compound 4 ended at the assay's limit; the forecaster's own chance of this, stated with the estimate: 5%; middle value at least 12-fold (1.09 log units) from the limit.
By their numbers in this assay, from the lowest: compound 3; then compound 2; then compound 1. At a limit, above all of these: compound 4.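

In this assay compound 4 gives > 10000 nM, which is a limit of the assay and not a number: the limit of > 10000 nM in this assay, at which 1 of the 4 values shown sits. At the carbonyl carbon a nitrogen-containing six-membered aromatic ring is not enough in itself: the series shows an at least 27-fold higher number from compound 3 to compound 4 (1.43 log units; beyond the scatter) and an at least 4.4-fold higher number from compound 2 to compound 4 (0.64 log units; beyond the scatter), so the lower number seen with pyridin-2-yl does not carry over to 2-amino-4-methylpyrimidin-5-yl. The remaining step, an at least 1.0-fold higher number from compound 1 to compound 4 (0.03 log units; that floor lies within the scatter), cannot be read.

The compounds shown do not separate the contributions of the amine, the methyl and the ring nitrogens of the entering group. From the compounds shown here alone, how a plain pyrimidin-5-yl group on the carbonyl carbon would read against compound 3 and compound 4 remains open.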